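Amide substituent change and microsomal stability in the series

A few compounds are considered here, and "the series" means these few. Any claim that something is new, unique, unknown or untested is made for them only; others in the source may bear on it.

Among the measured compounds shown here, compound 1 `C[C@]1(C(=O)O)CC[C@H](C(=O)N2CC[C@](c3ccc(C(F)(C(F)(F)F)C(F)(F)F)cc3)(S(=O)(=O)c3ccc(F)cc3)C2)CC1` stands highest of the two numbers measured so far: in an ADME assay on microsomes from liver (Homo sapiens) for metabolic stability, with a stated time of 10 min (a higher number here means that more of the compound is left, a lower number that less of the compound is left), compound 1 gives 97%. Its nearest measured neighbour, compound 2 `O=C([C@H]1CC[C@H](CO)CC1)N1CC[C@](c2ccc(C(F)(C(F)(F)F)C(F)(F)F)cc2)(S(=O)(=O)c2ccc(F)cc2)C1`, gives 75% in this assay. Compound 3 `CC1(C(=O)N2CC[C@](c3ccc(C(F)(C(F)(F)F)C(F)(F)F)cc3)(S(=O)(=O)c3ccc(F)cc3)C2)CCS(=O)(=O)CC1` gives "not determined" (no result reported) in this assay. Compound 4 `CCC1(C(=O)N2CC[C@](c3ccc(C(F)(C(F)(F)F)C(F)(F)F)cc3)(S(=O)(=O)c3ccc(F)cc3)C2)CCS(=O)(=O)CC1` differs from compound 1 by 4-ethyl-1,1-dioxothian-4-yl in place of 4-carboxy-4-methylcyclohexyl on a carbonyl carbon. For the measured compounds named here, the one measured step that bears on this change is a number 22 percentage points lower from compound 1 to compound 2 (beyond the scatter), which also replaced the 4-carboxy-4-methylcyclohexyl group on the carbonyl carbon. As the change to compound 4 removes the same group, a downward step of comparable size, beyond the scatter, is expected in this assay. Compound 4 is therefore estimated at 70%, within 45% to 90%, an expected step of a number 27 percentage points lower from compound 1 to compound 4 (beyond the scatter).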

Compound 4, percent of the compound remaining: 3%
Beside the measured number, compound 4's estimate is 67 percentage points above it; the whole stated range lies above it.
By their numbers in this assay, from the lowest: compound 4; then compound 2; then compound 1.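

In this assay the position on the carbonyl carbon proves far less forgiving than the earlier pair suggested: 4-ethyl-1,1-dioxothian-4-yl gives a number 94 percentage points lower from compound 1 to compound 4 (beyond the scatter) and also a number 72 percentage points lower from compound 2 to compound 4 (beyond the scatter) when set against the 4-(hydroxymethyl)cyclohexyl group. Both steps are large, while a number 22 percentage points lower from compound 1 to compound 2 (beyond the scatter) remains modest among the groups with a carbon-only ring.

Going by these compounds, whether the ring sulfur, the ethyl group or the missing carboxylic acid carries the loss stays open, as does the outcome for a 4-aminocyclohexyl group at this position. No measurement shown gives a cause for the loss.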